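Benzamide for Butanamide: Expected Cell Tolerance of Compound 4

The source may hold more compounds than are shown below. What is called first, only, known or untested is meant among the compounds shown, and "the series" means these compounds.

Compound 3 `CCCC(=O)Nc1ncc(-c2ccc(OC)cc2)n1C` was tested in a toxicity assay on THP-1 cells (Homo sapiens) for inhibition (a higher number here means that more compound is tolerated, a lower number that less compound is tolerated), where compound 3 gives > 100000 nM, a limit of the assay rather than a number. Compound 1 `Cn1c(-c2ccc(C#N)cc2)cnc1NC(=O)c1ccc(F)cc1` likewise gives only a limit, > 50000 nM. Compound 2 `Cn1c(-c2ccc(Cl)cc2)cnc1NC(=O)c1ccc(F)cc1` gives 37000 nM. Among the compounds with values here, the only measured step is an at least 1.3-fold lower number from compound 1 to compound 2 (0.13 log units; that floor lies within the scatter), and it concerns a different part of the molecule, so it gives no direct guide to the change at hand. Compound 4 `COc1ccc(-c2cnc(NC(=O)c3ccccc3Cl)n2C)cc1` differs from compound 3 by 2-chlorophenyl in place of propyl on a carbonyl carbon. Compounds 1 and 2, which both carry an aromatic ring on the carbonyl carbon, sit at or not far from the limit. Compound 4 is therefore expected to give 50000 nM, between 20000 nM and 150000 nM. The step of an at least 2.0-fold lower number from compound 3 to compound 4 (0.30 log units; that floor lies within the scatter) is thus estimated to stay within the scatter.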

Compound 4, half-maximal cytotoxic concentration: > 50000 nM
Compound 4 gave a limit, no number; the forecaster's own chance of this, stated with the estimate: 50%; the middle value lies on the limit itself.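

Compound 3 and compound 4 each give only a limit of the assay, not a number, and the step between them cannot be read. The compounds shown leave open whether 2-chlorophenyl in place of propyl changes cell tolerance at all.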